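A few compounds are considered here, and "the series" means these few. Any claim that something is new, unique, unknown or untested is made for them only; others in the source may bear on it.

Three compounds share one core and differ only in the aryl group on the amide nitrogen. Compound 1 `Cc1occc1-c1nnc(SCC(=O)Nc2ccc(F)cc2)n1Cc1ccco1` carries a 4-fluorophenyl there; in a functional assay on CHO cells for antagonist activity at Orexin/Hypocretin receptor type 1 (Homo sapiens), read by FLIPR and calcium flux (on this read-out higher numbers stand for weaker inhibition and lower numbers for stronger inhibition), compound 1 gives > 15800 nM, which is a limit of the assay rather than a number. Compound 2 `Cc1occc1-c1nnc(SCC(=O)Nc2cccc(F)c2)n1Cc1ccco1` carries a 3-fluorophenyl; in this assay compound 2 gives > 15800 nM, again a limit of the assay. For the measured compounds named here, compound 3 `Cc1occc1-c1nnc(SCC(=O)Nc2cccc(Cl)c2)n1Cc1ccco1` carries a 3-chlorophenyl, and in this assay compound 3 gives 2000 nM, the only true number among the three, because the other two values sit at the limit of > 15800 nM in this assay, at which 2 of the 3 values shown sit. The step of an at least 7.9-fold lower number from compound 1 to compound 3 (0.89 log units; beyond the scatter) and the step of an at least 7.9-fold lower number from compound 2 to compound 3 (0.89 log units; beyond the scatter) show that exchanging fluoro for chloro brings a clearly stronger result. The step that the two limits leave unreadable from compound 1 to compound 2 cannot be read from the two limits.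

Compound 4 `COc1ccccc1NC(=O)CSc1nnc(-c2ccoc2C)n1Cc1ccco1` replaces the 3-chlorophenyl of compound 3 with a 2-methoxyphenyl on the same amide-type nitrogen (2-methoxyphenyl in place of 3-chlorophenyl on an amide-type nitrogen). Going by the values given here, no measured step covers a methoxy group, and the only group that gave a number was the chlorine. Since compound 3 owes its number to that chlorine, compound 4 is expected to lose ground, with a step of a 4.0-fold higher number from compound 3 to compound 4 (0.60 log units; beyond the scatter) in this assay. The estimate for compound 4 is therefore 8000 nM, within a range from 2500 nM to 20000 nM.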

Compound 4, inhibition constant: > 15800 nM
Compound 4 gave a limit, no number; the forecaster's own chance of this, stated with the estimate: 40%; at least 1.9-fold (0.29 log units) between middle value and limit.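

Putting 2-methoxyphenyl in place of 3-chlorophenyl on the amide-type nitrogen gives an at least 7.9-fold higher number from compound 3 to compound 4 (0.89 log units; beyond the scatter) in this assay, so this position now loses its measurable result with a group that carries no halogen as well as with the two fluorophenyl groups. For the compounds shown here, compound 3 remains the only one of the four compounds with a true number, and its 3-chlorophenyl is the only group here that gives one, while the 4-fluorophenyl, 3-fluorophenyl and 2-methoxyphenyl groups all go against any broad tolerance at this position. The steps from compound 1 and from compound 2 to compound 4 cannot be read, because both ends of each step are limits of the assay and not numbers: the limit of > 15800 nM in this assay, at which 3 of the 4 values shown sit.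

Going from 3-chlorophenyl to 2-methoxyphenyl changes both the group on the ring and its numbered place at once, so the compounds shown cannot say which of the two changes matters. Going by these compounds, it also remains open whether the result at compound 3 belongs to chlorine alone, or whether a bromo, a trifluoromethyl or an amine on the same phenyl ring would also give a number.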